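The source may hold more compounds than are shown below. What is called first, only, known or untested is meant among the compounds shown, and "the series" means these compounds.

Compound 2, `COc1cc(C(C)C(=O)NCc2ccc(C(F)(F)F)nc2N2CCC(C)CC2)ccc1NS(C)(=O)=O`, is the stronger of two measured compounds: in an assay on cells for antagonist activity at transient receptor potential cation channel subfamily V member 1 (Homo sapiens), read by FLIPR and calcium flux, with a stated time of 15 min (on this read-out lower numbers stand for stronger inhibition and higher numbers for weaker inhibition), compound 2 gives 0.8 nM, the lowest of the two numbers. Going by the values given here, its neighbour compound 1, `CC1CCN(c2nc(C(F)(F)F)ccc2CNC(=O)C(C)c2ccc(NS(C)(=O)=O)c(Cl)c2)CC1`, gives 2.3 nM in this assay, and the step of a 2.9-fold lower number from compound 1 to compound 2 (0.46 log units; beyond the scatter) came from the single change of a methoxy in place of chloro on an aromatic carbon.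

Compound 3, `COc1cc(C(C)C(=O)NCc2ccc(C(F)(F)F)nc2N2CCC(C)CC2)cc(OC)c1NS(C)(=O)=O`, is not yet measured. It differs from compound 2 by methoxy in place of hydrogen on an aromatic carbon. Among the compounds with values here, no measured step covers the addition of a second methoxy; the only step known, from compound 1 to compound 2, concerns a swap rather than an addition, and it was modest. With so little to go on, the expected step of a 1.5-fold higher number from compound 2 to compound 3 (0.18 log units; within the scatter) is small and may well fall within the scatter, in either direction. Compound 3 is therefore expected to give about 1.2 nM in this assay, within a range of 0.3 nM to 5 nM.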

Compound 3, inhibition constant: 1.6 nM
Estimate against measurement, compound 3: 1.3-fold (0.12 log units) below, and the stated range covers the measured number.
By their numbers in this assay, from the lowest: compounds 2, 3 and 1 (each within the scatter of the next, the first and the last beyond it).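

In this assay, placing a methoxy on the aromatic carbon ortho to the methanesulfonamido group, where compound 2 carries only hydrogen, gives a 2.0-fold higher number from compound 2 to compound 3 (0.30 log units; within the scatter), so the two numbers cannot be told apart. The earlier step, a 2.9-fold lower number from compound 1 to compound 2 (0.46 log units; beyond the scatter), was a swap of chloro for methoxy, whereas this one shows that an added methoxy at this second position leaves the number within the scatter. No supporting measurement bears on what lies behind this result.

On these data alone, one added group at one position says little about that position in general, so it remains open whether a smaller or differently built group, such as fluoro, hydroxyl or an amine, would also leave the number within the scatter. As far as these compounds go, it is also open whether a longer chain, such as ethoxy, would do the same.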